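Moving the Halogen Around the Benzyl Ring

The source may hold more compounds than are shown below. What is called first, only, known or untested is meant among the compounds shown, and "the series" means these compounds.

Compound 1 `O=c1ccoc2cc(OCc3cn(Cc4ccccc4Br)nn3)ccc12` carries a 2-bromophenyl on a saturated chain carbon bound to an aromatic nitrogen. In a functional assay on HeLa cells (Homo sapiens) for cytotoxicity, read by MTT assay, with a stated time of 48 h (on this read-out higher numbers stand for weaker inhibition and lower numbers for stronger inhibition), compound 1 gives 14500 nM, the lowest of the two numbers available here. Compound 3 `O=c1ccoc2cc(OCc3cn(Cc4ccc(Cl)cc4)nn3)ccc12` gives 37600 nM, a step of a 2.6-fold higher number from compound 1 to compound 3 (0.41 log units; beyond the scatter). Compound 2 `O=c1ccoc2cc(OCc3cn(Cc4cccc(Br)c4)nn3)ccc12` reaches only a limit of this assay, > 100000 nM, so its true number is not known beyond that limit (the limit of > 100000 nM in this assay, at which 1 of the 3 values shown sits).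

Compound 4 `O=c1ccoc2cc(OCc3cn(Cc4cccc(Cl)c4)nn3)ccc12` differs from compound 1 by 3-chlorophenyl in place of 2-bromophenyl on a saturated chain carbon bound to an aromatic nitrogen. The measured step that bears most directly on this change is an at least 6.8-fold higher number from compound 1 to compound 2 (0.83 log units; beyond the scatter), in which bromine moves to the position that chlorine takes in compound 4, and the comparison an at least 2.6-fold lower number from compound 2 to compound 3 (0.42 log units; beyond the scatter) also places the 3-bromophenyl compound at the weak end. A clearly weaker number is therefore expected for compound 4, quite possibly at the limit again. Compound 4 is estimated to give 80000 nM, with a plausible range from 30000 nM to 200000 nM. That estimate means an expected step of a 5.5-fold higher number from compound 1 to compound 4 (0.74 log units; beyond the scatter).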

Compound 4, half-maximal inhibitory concentration: > 100000 nM
Compound 4 was reported as a limit; the forecaster's own chance of this, stated with the estimate: 45%; middle value at least 1.2-fold (0.09 log units) away from the limit.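

Compound 4 shows that the loss seen with the 3-bromophenyl group in compound 2 is not confined to bromine, as the 3-chlorophenyl group also gives much weaker inhibition in this assay, with an at least 6.8-fold higher number from compound 1 to compound 4 (0.83 log units; beyond the scatter). Two compounds that both carry chlorine also separate, with an at least 2.6-fold higher number from compound 3 to compound 4 (0.42 log units; beyond the scatter), so the place of the halogen on the ring matters here and not only which halogen it is. The step between compound 2 and compound 4 cannot be read, so bromine and chlorine cannot be ranked at this place: the limit of > 100000 nM in this assay, at which 2 of the 4 values shown sit.

As far as these compounds go, a 2-chlorophenyl group would show whether the number of compound 1 depends on bromine itself, and that remains open. Also open, from the compounds shown here alone, is how an amine or a methoxy group on the same ring would compare with the halogens.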